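Swapping Nitrooxy for Cyano on the Sulfonyl Aryl Ring

The compounds below may be only part of what the source reports. "The series", "measured", "known", "first", "only" and "open" are said of these compounds alone.

Three compounds have been measured in an ADME assay on L02 cells (Homo sapiens) for cytotoxicity, read by MTT assay, with a stated time of 24 h; a lower number here means a stronger inhibitor, a higher number a weaker inhibitor:

Compound 1 `O=C1/C(=C/c2ccccc2F)CN(S(=O)(=O)c2ccc(Cl)cc2)C/C1=C\c1ccccc1F`: 14100 nM
Compound 2 `CC(=O)Nc1ccc(S(=O)(=O)N2C/C(=C\c3ccccc3F)C(=O)/C(=C/c3ccccc3F)C2)cc1`: 11500 nM
Compound 3 `O=C1/C(=C/c2ccc(F)cc2)CN(S(=O)(=O)c2ccc(O[N+](=O)[O-])cc2)C/C1=C\c1ccc(F)cc1`: 16200 nM

All three numbers sit close together. Compound 3 has the highest of the three numbers, yet its gaps to compound 1 and to compound 2 both lie within the scatter of repeated measurements, so no order among them can be claimed. Within the data shown here, the one measured step, a 1.2-fold lower number from compound 1 to compound 2 (0.09 log units; within the scatter), likewise exchanges a single group on an aromatic carbon and moves the number by no more than the scatter.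

Compound 4 `N#Cc1ccc(S(=O)(=O)N2C/C(=C\c3ccc(F)cc3)C(=O)/C(=C/c3ccc(F)cc3)C2)cc1` has not yet been measured. It differs from compound 3 in one place: cyano in place of nitrooxy on an aromatic carbon. Among the measured compounds shown here, the single step that bears on this kind of change, from compound 1 to compound 2, was within the scatter, so a step of similar size is expected here: compound 4 is expected to differ from compound 3 by a 1.2-fold lower number from compound 3 to compound 4 (0.06 log units; within the scatter), with no direction beyond the scatter. For compound 4 the expected number in this assay is 14000 nM, with a range from 7000 nM to 28000 nM.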

Compound 4, half-maximal inhibitory concentration: 14700 nM
Estimate against measurement, compound 4: 1.1-fold (0.02 log units) below; the measured number falls inside the stated range.
By their numbers in this assay, from the lowest: compounds 2, 1, 4 and 3 (each within the scatter of the next).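

In this assay, the place para to a large group now has a second exchange of a single group, and a 1.1-fold lower number from compound 3 to compound 4 (0.04 log units; within the scatter) stays within the scatter. The earlier step at this place belonged to the core of compound 1, while this one belongs to the core of compound 3, so a flat result now appears on both cores, even though the nitrooxy group that leaves has more heavy atoms than the cyano group that enters. No supporting measurement offers a reason for this flat result.

As far as these compounds go, whether a carboxylic acid, an amine or a longer chain at this place would move the number beyond the scatter stays open. So does whether any group here matters at all for this cytotoxicity read-out, since only a few groups have been compared.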